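Shifting a chlorine on the pyridine ring of compound 3

The source may report more compounds than this note shows. Statements on the series, on what has been measured and on what is new or still open speak of the compounds shown alone.

Of the compounds shown here, three sharing one core have been measured in an ADME assay for permeability, using PAMPA; on this read-out higher numbers stand for higher permeability and lower numbers for lower permeability. Compound 1 `C/C=C/C(=O)Nc1cccc(-c2nc3ccccc3s2)c1` gives 1640 10^-6 cm/s. Compound 2 `O=C(O)/C=C/C(=O)Nc1cccc(-c2nc3ccccc3s2)c1` gives 4 10^-6 cm/s. Compound 3 `O=C(Nc1cccc(-c2nc3ccccc3s2)c1)c1cnccc1Cl` gives 732 10^-6 cm/s, the second highest of the three numbers; its nearest neighbour is compound 1, and its furthest is compound 2.

Compound 4 `O=C(Nc1cccc(-c2nc3ccccc3s2)c1)c1cccnc1Cl` differs from compound 3 in one place: 2-chloropyridin-3-yl in place of 4-chloropyridin-3-yl on a carbonyl carbon. The two have the same atoms, joined differently, so nothing is added or removed, and the count of hydrogen-bond donors and acceptors stays the same.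

Of the steps already measured, none moves a chlorine within a ring. The step of a 410-fold lower number from compound 1 to compound 2 (2.61 log units; beyond the scatter) and the step of a 180-fold higher number from compound 2 to compound 3 (2.26 log units; beyond the scatter) were large, but both involve a carboxy group, which compound 4 does not carry. The step of a 2.2-fold lower number from compound 1 to compound 3 (0.35 log units; beyond the scatter) was modest and exchanged a whole chain for a ring. None of these bears directly on the change from compound 3 to compound 4, so no step beyond the scatter in this assay is expected, in either direction; the estimated step is a 1.0-fold lower number from compound 3 to compound 4 (0.02 log units; within the scatter).

Compound 4 is therefore estimated at 700 10^-6 cm/s, expected to fall between 350 10^-6 cm/s and 1400 10^-6 cm/s.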

Compound 4, apparent permeability: 677 10^-6 cm/s
Beside the measured number, compound 4's estimate is 1.0-fold (0.01 log units) above it; low and high end bracket the measured number.
By their numbers in this assay, from the lowest: compound 2; then compounds 4 and 3 (each within the scatter of the next); then compound 1.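

In this assay, the two chlorine placements can now be compared directly: with 2-chloropyridin-3-yl in place of 4-chloropyridin-3-yl on the carbonyl carbon, the result is a 1.1-fold lower number from compound 3 to compound 4 (0.03 log units; within the scatter) for this swap of one atom's place on the ring, and so, for this pair, the read-out does not separate the two isomers. The new compound also stands apart from the other two much as compound 3 does, with a 170-fold higher number from compound 2 to compound 4 (2.23 log units; beyond the scatter) as a large step and a 2.4-fold lower number from compound 1 to compound 4 (0.38 log units; beyond the scatter) as a modest one, so the same pattern of sizes holds for both chloropyridine amides. Nothing measured here offers an explanation for why the two placements read alike.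

From the compounds shown here alone, this pair covers only a chlorine moved between two places on one pyridine ring, so it remains open whether a methyl, a methoxy or an amine in those same places would also leave the number within the scatter. The compounds shown also leave open how a plain pyridin-3-yl, carrying no chlorine at all, would compare with compound 3 and compound 4 on this same read-out.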